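Swapping Phenyl for Methyl on a Shared Core

The compounds below may be only part of what the source reports. "The series", "measured", "known", "first", "only" and "open" are said of these compounds alone.

Compound 1 `CCOC(=O)c1c(C)nc(NCCNc2ccnc3cc(Cl)ccc23)nc1-c1ccccc1` and compound 2 `CCOC(=O)c1c(C)nc(NCCCCNc2ccnc3cc(Cl)ccc23)nc1-c1ccccc1` share a core that carries an ethoxycarbonyl group, a methyl group and a phenyl group. In an ADME assay on MDCK cells (Canis lupus familiaris) for cytotoxicity, read by microscopy (a lower number here means that less compound is tolerated, a higher number that more compound is tolerated), compound 1 gives 800 nM and compound 2 gives 800 nM; the two values sit level with each other, within the scatter of the method. Compound 3 `CCOC(=O)c1c(C)nc(NCCCCNc2ccnc3cc(Cl)ccc23)nc1C` is the same as compound 2 except for one change: methyl in place of phenyl on an aromatic carbon. Among the measured compounds shown here, no measured pair here reports such a change, so the direction is open. A modest rise in tolerated concentration is expected, as a 1.9-fold higher number from compound 2 to compound 3 (0.27 log units; within the scatter), giving for compound 3 an estimate of 1500 nM with a range from 500 nM to 5000 nM.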

Compound 3, minimum cytotoxic concentration: 4000 nM
The estimate for compound 3 lay 2.7-fold (0.43 log units) below the measured number; low and high end bracket the measured number.
By their numbers in this assay, from the lowest: compounds 1 and 2 (each within the scatter of the next); then compound 3.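

In this assay, methyl in place of phenyl on this aromatic carbon gives a 5.0-fold higher number from compound 2 to compound 3 (0.70 log units; beyond the scatter), a step beyond the scatter, so this position can shift the tolerated concentration in a way the level pair of compound 1 and compound 2 did not show. Replacing the phenyl ring with a single carbon is therefore tolerated here, and the data offer no explanation for the rise. On these data alone, whether a cyclohexyl group, an ethyl group or an amine at this position would behave like methyl stays open. So does whether the same swap would have this effect on the chain of compound 1.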